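Notes on bromo substitution from compound 3 to compound 4

The compounds below may be only part of what the source reports. "The series", "measured", "known", "first", "only" and "open" are said of these compounds alone.

Values in a physicochemical assay for lipophilicity, at pH 7.4 (on this read-out higher numbers stand for higher lipophilicity and lower numbers for lower lipophilicity), so far are these.
compound 1 `CCCCCCCCCc1c(C)[nH]c2ccccc2c1=O` gives 4.33
compound 2 `Cc1[nH]c2ccccc2c(=O)c1C1CCCCC1` gives 2.45
compound 3 `Cc1[nH]c2ccccc2c(=O)c1Br` gives 1.67

In this assay compound 3 stands lowest of the three, with compound 2 nearest and compound 1 furthest. The next compound is compound 4 `Cc1[nH]c2ccc(Br)cc2c(=O)c1Br` and the change is bromo in place of hydrogen on an aromatic carbon in all, bromo in place of hydrogen on an aromatic carbon of a six-membered aromatic ring of carbon only.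

Within the data shown here, one measured step bears on this, and only loosely: a number 0.78 log units lower from compound 2 to compound 3 (beyond the scatter) where bromo replaces cyclohexyl on an aromatic carbon. That step is modest but beyond the scatter. Among the measured compounds shown here, no measured step replaces hydrogen with bromo, so the size of the new step rests on this single, imperfect comparison. A modest upward step of similar size is expected, beyond the scatter. The estimate amounts to an expected rise of a number 0.73 log units higher from compound 3 to compound 4 (beyond the scatter) in this series. For compound 4 the estimated value is 2.4 with an expected range of 2 to 2.9 in this assay when measured.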

Compound 4, distribution coefficient: 1.76
For compound 4 the middle estimate is 0.64 log units above the measured one, and the stated range ends above it.
By their numbers in this assay, from the lowest: compounds 3 and 4 (each within the scatter of the next); then compound 2; then compound 1.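

In this assay, bromo in place of hydrogen on an aromatic carbon of a six-membered aromatic ring of carbon only gives a number 0.09 log units higher from compound 3 to compound 4 (within the scatter) and so leaves the two compounds indistinguishable on this read-out. Among these compounds, this is the only measured change at this position, as the earlier compounds vary at a single different place on the shared core, and it shows that a bromo here need not separate two compounds in this assay. Nothing measured here offers an explanation for this result.

On these data alone, it remains open whether another group at this position, such as an amine, a carboxylic acid or a longer chain, would move the read-out beyond the scatter. Also open, as far as these compounds go, is whether the same bromo change would give a similar result on compound 2, which carries cyclohexyl in place of the first bromo.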